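A few compounds are considered here, and "the series" means these few. Any claim that something is new, unique, unknown or untested is made for them only; others in the source may bear on it.

In a functional assay on NCI-H226 cells (Homo sapiens) for cytotoxicity, read by sulforhodamine B assay, with a stated time of 48 h (on this read-out lower numbers stand for stronger inhibition of growth and higher numbers for weaker inhibition of growth), compound 1 `ClCc1cccc(Cn2cnc3c(Cl)ncnc32)c1` gives 14400 nM. Compound 2 `ClCc1cccc(Cn2cnc3c(Cl)nc(Cl)nc32)c1` carries chloro in place of hydrogen on an aromatic carbon and in this assay compound 2 gives 10000 nM, so that the step is a 1.4-fold lower number from compound 1 to compound 2 (0.16 log units; within the scatter). Compound 3 `ClCc1ccccc1Cn1cnc2ncnc(Cl)c21` has a core of its own; how it differs from the core of compound 1 is not broken down here. In this assay compound 3 gives 7940 nM. Compound 4 `ClCc1ccccc1Cn1cnc2nc(Cl)nc(Cl)c21` is not yet measured and carries chloro in place of hydrogen on an aromatic carbon, the same change made from compound 1 to compound 2, which occurs twice among the compounds shown. Because that earlier step was a 1.4-fold lower number from compound 1 to compound 2 (0.16 log units; within the scatter), a step of similar size is expected for compound 4 in this assay, namely a 1.4-fold lower number from compound 3 to compound 4 (0.15 log units; within the scatter). Compound 4 is therefore expected to give about 5600 nM, most likely between 2500 nM and 12500 nM.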

Compound 4, concentration for total growth inhibition: 6760 nM
For compound 4 the middle estimate is 1.2-fold (0.08 log units) below the measured one, and the stated range covers the measured number.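

In this assay chloro in place of hydrogen on an aromatic carbon gives a 1.2-fold lower number from compound 3 to compound 4 (0.07 log units; within the scatter) and so matches the step seen on the core of compound 1: the same change on two cores in this assay, a 1.4-fold lower number (0.16 log units; within the scatter) from compound 1 to compound 2 and a 1.2-fold lower number (0.07 log units; within the scatter) from compound 3 to compound 4, 1.2-fold (0.09 log units) apart, within the scatter of two such steps. The change therefore carries from one core to the other with no difference that can be told apart. Neither step lies beyond the scatter, however, so no effect of the chloro on growth inhibition is shown, and two cores do not speak for any further core.

The compounds shown leave open what other groups, such as an amine or a methoxy group, would do at the place between two ring nitrogen atoms. They also leave open how a hydroxymethyl group in place of the chloromethyl group would stand in this assay.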